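Replacing the methoxyphenyl of compound 2 with a thiophene

This account rests on a few compounds, and the source may have more. Where it says the series, first, only, none or still open, it means among the compounds named here.

Three compounds share one core and differ only in the group attached to the carbonyl carbon: compound 1 `COc1ccc(-c2cc3ccccc3nc2/C=C/C(=O)c2ccc(F)cc2)cc1`, compound 2 `COc1ccc(C(=O)/C=C/c2nc3ccccc3cc2-c2ccc(OC)cc2)cc1` and compound 3 `COc1ccc(-c2cc3ccccc3nc2/C=C/C(=O)c2ccc(Br)s2)cc1`. In a functional assay on SK-BR-3 cells (Homo sapiens) for antiproliferative activity, read by XTT assay, with a stated time of 72 h (on this read-out higher numbers stand for weaker inhibition and lower numbers for stronger inhibition), compound 1 gives 810 nM, compound 2 gives 9280 nM and compound 3 gives 520 nM, so compound 2 stands highest of the three, with an 11-fold higher number from compound 1 to compound 2 (1.06 log units; beyond the scatter) and an 18-fold lower number from compound 2 to compound 3 (1.25 log units; beyond the scatter). Compound 4 `COc1ccc(-c2cc3ccccc3nc2/C=C/C(=O)c2ccsc2)cc1` is not yet measured; it differs from compound 2 by thiophen-3-yl in place of 4-methoxyphenyl on a carbonyl carbon. The most comparable measured step is an 18-fold lower number from compound 2 to compound 3 (1.25 log units; beyond the scatter), which points to a clearly lower number. The estimated step is a 9.3-fold lower number from compound 2 to compound 4 (0.97 log units; beyond the scatter), giving an expected value for compound 4 of 1000 nM, within 350 nM to 3000 nM.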

Compound 4, half-maximal inhibitory concentration: 660 nM
Compound 4: the middle estimate sits 1.5-fold (0.18 log units) above what was measured, and the stated range covers the measured number.
By their numbers in this assay, from the lowest: compounds 3, 4 and 1 (each within the scatter of the next); then compound 2.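

With thiophen-3-yl on the carbonyl carbon, a ring carrying no bromine also gives a large drop, a 14-fold lower number from compound 2 to compound 4 (1.15 log units; beyond the scatter), so the bromo group of compound 3 is not needed for it. The other two steps, a 1.3-fold higher number from compound 3 to compound 4 (0.10 log units; within the scatter) and a 1.2-fold lower number from compound 1 to compound 4 (0.09 log units; within the scatter), leave 4-fluorophenyl, 5-bromothiophen-2-yl and thiophen-3-yl indistinguishable here, with only the 4-methoxyphenyl of compound 2 standing apart. Nothing measured here explains why 4-methoxyphenyl differs.

Still open, going by these compounds, is how a group without an aromatic ring, such as a piperidine or a short alkyl chain, would read on this carbonyl carbon. Also open, on these data alone, is whether an amine in place of the methoxy would behave like the methoxy or like the fluoro.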